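Compound 1 to compound 4: sulfonyl replaced by sulfanyl

The source may hold more compounds than are shown below. What is called first, only, known or untested is meant among the compounds shown, and "the series" means these compounds.

In a functional assay on DU-145 cells (Homo sapiens) for inhibition, read by trypan blue exclusion, with a stated time of 96 h (on this read-out higher numbers stand for weaker inhibition of growth and lower numbers for stronger inhibition of growth), compound 1 `Cc1ccc(S(=O)(=O)/C(=C/c2c(O)cc(O)cc2O)C(=O)c2ccc(Br)cc2)cc1` gives > 100000 nM, a limit and not a number, and stands at the limit of > 100000 nM in this assay, at which 2 of the 3 values shown sit. Compound 2 `Cc1ccc(S(=O)(=O)/C(=C/c2c(O)cc(O)cc2O)C(=O)c2ccc(Cl)cc2)cc1` gives > 100000 nM, also a limit. Compound 3 `Cc1ccc(S(=O)(=O)/C(=C/c2ccc(N(C)C)cc2)C(=O)c2ccc(Br)cc2)cc1` gives 50000 nM.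

Compound 4 `O=C(/C(=C\c1c(O)cc(O)cc1O)Sc1ccccc1Br)c1ccc(Br)cc1` carries (2-bromophenyl)sulfanyl in place of (4-methylphenyl)sulfonyl on a double-bonded chain carbon bound to a carbonyl carbon and a double-bonded chain carbon. Among the measured compounds shown here, no measured step covers that place. The halogen change gives a step that the two limits leave unreadable from compound 1 to compound 2. Loss of the 2,4,6-trihydroxyphenyl group, which compound 4 keeps, gives an at least 2.0-fold lower number from compound 1 to compound 3 (0.30 log units; that floor lies within the scatter). No step beyond the scatter is therefore expected in this assay, and the expected step is a number no higher from compound 1 to compound 4 (the limit leaves the size open). For compound 4 the estimated value is 100000 nM, with an expected range of 25000 nM to 300000 nM.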

Compound 4, concentration for 50% growth inhibition: > 100000 nM
Compound 4: no number, only a limit; the forecaster's own chance of this, stated with the estimate: 55%; the middle value lies on the limit itself.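

Among the compounds shown here, compound 1 and compound 4 both stand at a limit, not a number, so no step between them can be read: the limit of > 100000 nM in this assay, at which 3 of the 4 values shown sit.

As far as these compounds go, whether (2-bromophenyl)sulfanyl in place of (4-methylphenyl)sulfonyl alters growth inhibition at all, and in which direction, stays open.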